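Swapping an aryl for isopropyl on the pyrazole nitrogen

The compounds below may be only part of what the source reports. "The series", "measured", "known", "first", "only" and "open" are said of these compounds alone.

Of the compounds shown here, three have been tested in an ADME assay on Huh-7 cells (Homo sapiens) for cytotoxicity; a lower number here means that less compound is tolerated, a higher number that more compound is tolerated. Compound 1 `CN1CCN(CCCNCc2cn(-c3ccc(C(F)(F)F)cc3)nc2-c2ccc(OC(F)(F)F)cc2)CC1` gives 2300 nM. Compound 2 `CN1CCN(CCNCc2cn(-c3ccc(F)cc3F)nc2C2CCCCC2)CC1` reaches only a limit of the assay, > 20000 nM, so no number is known for it. Compound 3 `Cc1ccccc1-c1nn(-c2ccc(Cl)cc2)cc1CNCCN1CCN(C)CC1` gives 17000 nM, the highest of the two real numbers; compound 1 sits well below it, beyond the usual scatter. Compound 4 `Cc1ccccc1-c1nn(C(C)C)cc1CNCCN1CCN(C)CC1` is not yet measured; it differs from compound 3 by isopropyl in place of 4-chlorophenyl on an aromatic nitrogen. Within the data shown here, with no measured pair showing this kind of change, the expected step in this assay is a 1.2-fold higher number from compound 3 to compound 4 (0.07 log units; within the scatter), most likely small or none beyond the scatter, leaning toward a higher number. Compound 4 is therefore estimated at 20000 nM, between 8000 nM and 50000 nM, possibly ending at the limit of > 20000 nM in this assay, at which 1 of the 3 values shown sits.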

Compound 4, half-maximal cytotoxic concentration: > 20000 nM
Compound 4 was reported as a limit; the forecaster's own chance of this, stated with the estimate: 50%; the middle value sits exactly at the limit.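

Replacing 4-chlorophenyl with isopropyl on the aromatic nitrogen removes a ring, and in this assay this one-place change gives an at least 1.1-fold higher number from compound 3 to compound 4 (0.07 log units; that floor lies within the scatter). So this position tolerates losing the aromatic ring with no fall in the number, though how far the number rises cannot be read. For compound 4 the result is a limit, not a number: the limit of > 20000 nM in this assay, at which 2 of the 4 values shown sit.

Still open, as far as these compounds go, is whether a methyl group, or a chain ending in an amine, on this nitrogen would keep the number as high. From the compounds shown here alone, it is also open whether the swap would act the same way with another group in place of 2-methylphenyl.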